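Compound 3 to compound 4: one stereocentre changed

The source may hold more compounds than are shown below. What is called first, only, known or untested is meant among the compounds shown, and "the series" means these compounds.

In a functional assay on LNCaP cells (Homo sapiens) for antiproliferative activity (on this read-out higher numbers stand for weaker inhibition and lower numbers for stronger inhibition), compound 1 (`Nc1nc(=O)n([C@H]2C=C[C@@H](CO)O2)cc1Br`) gives > 100000 nM, which is a limit of the assay. Compound 2 (`Nc1nc(=O)n([C@H]2C=C[C@@H](CO)O2)cc1I`) gives > 100000 nM, also a limit. Among the compounds with values here, compound 3 (`O=c1[nH]c(=O)n([C@@H]2C=C[C@@H](CO)O2)cc1F`) gives 85800 nM, the only actual number so far. The series is bounded by the limit of > 100000 nM in this assay, at which 2 of the 3 values shown sit.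

Compound 4 (`O=c1[nH]c(=O)n([C@@H]2C=C[C@H](CO)O2)cc1F`) relates to compound 3 through (the two compounds have the same atoms and bonds and differ only in configuration as drawn: 1 of 2 stereo elements differ; a stereocentre at a saturated ring carbon is drawn S in compound 3 and R in compound 4). Within the data shown here, the sole measured step, a step that the two limits leave unreadable from compound 1 to compound 2, concerns a different change and supplies no size for this one. No shift beyond the scatter is therefore expected in this assay, and a result reported only as a limit is quite possible. The expected step is a 1.0-fold higher number from compound 3 to compound 4 (0.02 log units; within the scatter). For compound 4 the estimated value is 90000 nM, with an expected range of 40000 nM to 130000 nM.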

Compound 4, half-maximal inhibitory concentration: 57200 nM
Compound 4: the middle estimate sits 1.6-fold (0.20 log units) above what was measured; low and high end bracket the measured number.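

In this assay, within the data shown here, this change of configuration at a saturated ring carbon, S in compound 3 and R in compound 4, gives the first readable step: a 1.5-fold lower number from compound 3 to compound 4 (0.18 log units; within the scatter). At this stereocentre, the S to R change therefore moves the read-out no further than the scatter. Compound 1 and compound 2 remain at a limit of the assay: the limit of > 100000 nM in this assay, at which 2 of the 4 values shown sit.

On these data alone, the effect of changing the other stereocentre remains open. Also open, as far as these compounds go, is whether this stereocentre matters as little with a methyl group or a chlorine atom in place of the fluorine on the shared core.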